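Series notes: from compound 3 to compound 4

The source may report more compounds than this note shows. Statements on the series, on what has been measured and on what is new or still open speak of the compounds shown alone.

Measured in a functional assay on PC-3 cells (Homo sapiens) for inhibition (a higher number here means a weaker inhibitor, a lower number a stronger inhibitor), so far:
compound 1 `COc1cc2nc(N3CCN(S(=O)(=O)c4ccc([N+](=O)[O-])cc4)CC3)nc(N)c2cc1OC` — 36000 nM
compound 2 `COc1cc2nc(N3CCN(S(=O)(=O)c4ccc(S(C)(=O)=O)cc4)CC3)nc(N)c2cc1OC` — 17000 nM
compound 3 `CCCCc1ccc(-c2ccc(S(=O)(=O)N3CCN(c4nc(N)c5cc(OC)c(OC)cc5n4)CC3)cc2)cc1` — 3400 nM

Compound 3 stands lowest of the three numbers: an 11-fold lower number from compound 1 to compound 3 (1.02 log units; beyond the scatter) and a 5.0-fold lower number from compound 2 to compound 3 (0.70 log units; beyond the scatter), with a 2.1-fold lower number from compound 1 to compound 2 (0.33 log units; beyond the scatter) between the other two. Compound 4 `COc1cc2nc(N3CCN(S(=O)(=O)c4ccc(-c5ccc(C(C)(C)C)cc5)cc4)CC3)nc(N)c2cc1OC` is the next member; the change is tert-butyl in place of butyl on an aromatic carbon. Among the measured compounds shown here, none of the measured steps covers this change: each of them replaced the group on that aromatic carbon with a different kind of group, whereas here the same atoms are joined differently and the 4-butylphenyl group that gave the large gain is kept. With no guidance, the expected step is none beyond the scatter, no change at the digits printed from compound 3 to compound 4 (within the scatter). Compound 4 is therefore estimated at 3400 nM, within 1500 nM to 8000 nM.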

Compound 4, half-maximal inhibitory concentration: 10000 nM
For compound 4 the middle estimate is 2.9-fold (0.47 log units) below the measured one, outside the stated range (above it).
By their numbers in this assay, from the lowest: compound 3; then compounds 4 and 2 (each within the scatter of the next); then compound 1.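

In this assay, among the compounds shown here, butyl and tert-butyl hold the same atoms joined differently, yet a 2.9-fold higher number from compound 3 to compound 4 (0.47 log units; beyond the scatter) shows that this place separates the two chains, whereas the earlier steps only exchanged different kinds of group. The 4-(tert-butyl)phenyl group still reads a 3.6-fold lower number from compound 1 to compound 4 (0.56 log units; beyond the scatter) against nitro, while against methylsulfonyl it reads a 1.7-fold lower number from compound 2 to compound 4 (0.23 log units; within the scatter) and so gives no clear separation. Nothing available explains why the two chains differ.

From the compounds shown here alone, whether a longer chain such as hexyl would extend the butyl result remains open. So does the outcome of an amine or a carboxylic acid in place of butyl.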